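The source may report more compounds than this note shows. Statements on the series, on what has been measured and on what is new or still open speak of the compounds shown alone.

Among the compounds with values here, in a functional assay on brain (Rattus norvegicus, strain Wistar) for inhibition (a lower number here means a stronger inhibitor, a higher number a weaker inhibitor), compound 1 (`CCCCOc1ccc(-c2c(C)[nH]c(=O)n2C)cc1`) gives 5100 nM, the lowest of the three numbers measured so far. Compound 2 (`CCCCc1ccc(-c2c(C)[nH]c(=O)n2C(C)C)cc1`) gives 10700 nM. Compound 3 (`CCCCOc1ccc(-c2c(C)[nH]c(=O)n2C2CCCCC2)cc1`) gives 13900 nM.

Still unmeasured is compound 4 (`Cc1[nH]c(=O)n(C)c1-c1ccc(CC(C)C)cc1`), in which isobutyl stands in place of butoxy on an aromatic carbon: isobutyl in place of butoxy on an aromatic carbon. Within the data shown here, only one measured step involves a single change, a 2.7-fold higher number from compound 1 to compound 3 (0.44 log units; beyond the scatter). It is modest, but it puts cyclohexyl in place of methyl on an aromatic nitrogen, so it says nothing direct about swapping butoxy for isobutyl. It serves only as a rough guide to how large a step in this small series can be. No single change links compound 1 to compound 2, so the value of compound 2 (10700 nM) offers only a weak hint towards a higher number.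

A modest move towards weaker inhibition is therefore expected in this assay, with an estimated step of a 1.6-fold higher number from compound 1 to compound 4 (0.20 log units; within the scatter). For compound 4 the estimated value is 8000 nM, with an expected range from 2800 nM to 22000 nM.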

Compound 4, half-maximal inhibitory concentration: 7800 nM
Estimate against measurement, compound 4: 1.0-fold (0.01 log units) above, and the stated range covers the measured number.
By their numbers in this assay, from the lowest: compounds 1, 4, 2 and 3 (each within the scatter of the next, the first and the last beyond it).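

In this assay, putting isobutyl in place of butoxy on this aromatic carbon gives a 1.5-fold higher number from compound 1 to compound 4 (0.18 log units; within the scatter), so the swap cannot be told apart from no change at all. This is the first single change shown at this position, and it shows that the oxygen of butoxy can go, with the chain reshaped into isobutyl, without the number moving beyond the scatter. No measurement shown here offers an explanation for this result.

The compounds shown leave open whether a longer chain such as hexyloxy, or a very different group such as an amine or a carboxylic acid, on this aromatic carbon would keep the number in the same range. Also open, going by these compounds, is whether the same swap would read alike in compound 3, which carries cyclohexyl on the aromatic nitrogen.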